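The compounds below may be only part of what the source reports. "The series", "measured", "known", "first", "only" and "open" are said of these compounds alone.

In an ADME assay on L929 cells (Mus musculus) for cytotoxicity, read by resazurin assay, with a stated time of 96 h (on this read-out higher numbers stand for lower toxicity in this test and lower numbers for higher toxicity in this test), the record for this small series is thin. For the measured compounds named here, compound 1 `NC(=S)N/N=C(/COc1ccc(Br)cc1)c1ccc(Cl)cc1` gives 25100 nM, the only single number available. Compound 2 `COc1ccc(/C(COc2ccc(Br)cc2)=N\NC(=S)Nc2ccccc2)cc1` has the entry "not determined" (no result reported). Compound 3 `CCc1ccc(OC/C(=N\NC(N)=S)c2ccc(Br)cc2)cc1` stands at < 25500 nM, which is a limit and not a number. Compound 4 `NC(=S)N/N=C(\COc1ccc(Cl)cc1)c1ccc(Br)cc1` differs from compound 3 as follows: chloro in place of ethyl on an aromatic carbon, para to a large group. Going by the values given here, no measured step shows what this change does in this assay, so the expectation rests on compound 1 at 25100 nM. The expected step that the limit leaves unreadable from compound 3 to compound 4 is none beyond the usual scatter. For compound 4 the estimated value is 20000 nM, with an expected range of 8000 nM to 32000 nM.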

Compound 4, half-maximal cytotoxic concentration: < 25100 nM
Compound 4: a limit, no number; the forecaster's own chance of this, stated with the estimate: 40%; the middle value is on the limit's open side.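

Compound 3 and compound 4 both carry only limits in this assay, so no step can be read between them. As far as these compounds go, what chloro in place of ethyl does in this test remains open.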